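The compounds below may be only part of what the source reports. "The series", "measured", "known", "first", "only" and "open" are said of these compounds alone.

Measured compounds in an assay on cells for inhibition of HSP60/HSP10 (Homo sapiens), with a stated time of 60 min; on this read-out lower numbers stand for stronger inhibition and higher numbers for weaker inhibition: compound 1 `O=S(=O)(Nc1ccc(-c2nc3ccccc3o2)cc1)c1cccc(O)c1` gives 62000 nM; compound 2 `O=S(=O)(Nc1ccc(-c2nc3ccccc3o2)cc1)c1ccc(F)cc1` gives 73000 nM.

Compound 2 and compound 1 lie within the scatter of each other on this assay, so neither can be placed above the other. Among the measured compounds shown here, the only measured step, a 1.2-fold higher number from compound 1 to compound 2 (0.07 log units; within the scatter), concerns the aryl group on the sulfonyl sulfur, the same position that is changed next. Compound 3 `Cc1ccccc1S(=O)(=O)Nc1ccc(-c2nc3ccccc3o2)cc1` differs from compound 2 as follows: 2-methylphenyl in place of 4-fluorophenyl on a sulfonyl sulfur. For the measured compounds named here, that single prior step at this position was within the scatter, and nothing among the measured compounds points to a stronger effect for this exchange. For compound 3 the expected step from compound 2, a 1.0-fold lower number from compound 2 to compound 3 (0.02 log units; within the scatter), is therefore none beyond the scatter. Compound 3 is estimated at 70000 nM, with a range from 25000 nM to 200000 nM, in this assay.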

Compound 3, half-maximal inhibitory concentration: 85000 nM
The estimate for compound 3 lay 1.2-fold (0.08 log units) below the measured number; measured number inside the range.
By their numbers in this assay, from the lowest: compounds 1, 2 and 3 (each within the scatter of the next).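

In this assay, 2-methylphenyl in place of 4-fluorophenyl on a sulfonyl sulfur gives a 1.2-fold higher number from compound 2 to compound 3 (0.07 log units; within the scatter), and 2-methylphenyl in place of 3-hydroxyphenyl gives a 1.4-fold higher number from compound 1 to compound 3 (0.14 log units; within the scatter). With a third aryl group at this position, all three pairs among compound 1, compound 2 and compound 3 now lie within the scatter, so 2-methylphenyl, 4-fluorophenyl and 3-hydroxyphenyl cannot be ranked on this read-out. No accompanying data speak to why these groups give such similar numbers.

Still open, as far as these compounds go, is whether any group on the sulfonyl sulfur can move the number beyond the scatter, for example a phenyl carrying an amine or a carboxylic acid, or a longer alkyl chain in place of the aryl group. The compounds shown also leave open how changes at the sulfonamide nitrogen or in the shared core would read out.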